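The source may report more compounds than this note shows. Statements on the series, on what has been measured and on what is new or still open speak of the compounds shown alone.

Compound 1 `COc1ccccc1N1CCN(CCCNc2ccncc2C(=O)N(C(C)C)C(C)C)CC1`: 251 nM
Compound 2 `COc1ccccc1N1CCN(CCCNc2ccccc2C(=O)c2ccccc2)CC1`: 10 nM
Compound 3 `CCOc1ccccc1N1CCN(CCCNc2ncccc2C(=O)N(C)C)CC1`: 7.94 nM

Of the compounds shown here, three have been measured in a functional assay on aorta for antagonist activity at Alpha-1D adrenergic receptor (Rattus norvegicus); a lower number here means tighter binding, a higher number weaker binding. Compound 1 gives 251 nM, compound 2 gives 10 nM, and compound 3 gives 7.94 nM. Compound 3 holds the lowest number of the three, but its nearest neighbour, compound 2, lies within the scatter of it, so no order can be drawn between those two. Compound 1 sits well beyond the scatter above both.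

Compound 4 `CN(C)C(=O)c1cccnc1NCCCN1CCN(c2ccccc2Cc2ccccc2)CC1` has not yet been measured in this assay. It differs from compound 3 in one place: benzyl in place of ethoxy on an aromatic carbon. For the measured compounds named here, no pair of measured compounds differing in a single place is available, so the size of such a change cannot be read from a measured step, and nothing among the measured compounds shows how a benzyl on an aromatic carbon of this ring behaves. The expectation is a moderate rise in number, that is weaker binding, somewhat beyond the scatter; the step is estimated at a 3.8-fold higher number from compound 3 to compound 4 (0.58 log units; beyond the scatter). Compound 4 is accordingly expected to give about 30 nM in this assay, with a range from 6 nM to 150 nM.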

Compound 4, dissociation constant: 79.4 nM
Compound 4: middle estimate off by 2.6-fold (0.42 log units), on the low side; low and high end bracket the measured number.
By their numbers in this assay, from the lowest: compounds 3 and 2 (each within the scatter of the next); then compound 4; then compound 1.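

In this assay, for the compounds shown here, the step of a 10-fold higher number from compound 3 to compound 4 (1.00 log units; beyond the scatter) gives the first direct reading of a single change in this set: benzyl in place of ethoxy on an aromatic carbon, ortho to a large group, moves the number beyond the scatter toward weaker binding. The position is therefore sensitive to what it carries, as replacing ethoxy, with 3 heavy atoms and 1 hydrogen-bond acceptor, with benzyl, with 7 heavy atoms, one aromatic ring and 0 hydrogen-bond acceptors, leaves compound 4 at 79.4 nM in this assay, so the change weakens binding without abolishing it. Nothing available explains the size or direction of this step, which stands as an observation only.

Going by these compounds, with only ethoxy and benzyl compared on this core, it remains open whether an ethyl, a phenyl, a phenoxy or a benzyloxy at this place would give a number closer to that of compound 3 or to that of compound 4. On these data alone, it is also open whether benzyl would produce a step of similar size on the cores of compound 1 and compound 2.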